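From a Carboxy Limit to a 4-Propylcyclohexyl Compound

A few compounds are considered here, and "the series" means these few. Any claim that something is new, unique, unknown or untested is made for them only; others in the source may bear on it.

Compound 1 `O=C1Nc2ccccc2/C1=N/NC(=S)Nc1cc(F)c(F)c(F)c1` gives 4410 nM
Compound 2 `O=C1Nc2ccccc2/C1=N/NC(=S)Nc1ccc(C(=O)O)cc1` gives > 50000 nM as a limit

In a functional assay on KB 3-1 cells (Homo sapiens) for cytotoxicity, read by MTT assay, with a stated time of 72 h (a higher number here means a weaker inhibitor, a lower number a stronger inhibitor), compound 2 gives > 50000 nM as a limit of the assay, not a number. Compound 3 `CCCC1CCC(c2ccc(NC(=S)N/N=C3\C(=O)Nc4ccccc43)cc2)CC1` differs from compound 2 in one place, 4-propylcyclohexyl in place of carboxy on an aromatic carbon with 4-propylcyclohexyl in place of carboxy on an aromatic carbon. Going by the values given here, no step between measured compounds is available to size this change, so any forecast rests on thin evidence. Compound 1, which also lacks the carboxy group, gives 4410 nM in this assay and so suggests that a measurable value is possible. A change towards stronger inhibition, beyond the usual scatter, is therefore expected. The expected size is an at least 8.3-fold lower number from compound 2 to compound 3 (0.92 log units; beyond the scatter) in this assay and remains an estimate. For compound 3 the estimated value is 6000 nM within an expected range of 1500 nM to 25000 nM in this assay.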

Compound 3, half-maximal inhibitory concentration: 17500 nM
Compound 3: middle estimate off by 2.9-fold (0.46 log units), on the low side, within the range that was stated.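

With 4-propylcyclohexyl in place of carboxy on this aromatic carbon, the series gains a readable value at this position: in this assay compound 3 gives 17500 nM. The change amounts to an at least 2.8-fold lower number from compound 2 to compound 3 (0.45 log units; beyond the scatter), which shows that this position, para to a large group, accepts a six-membered non-aromatic ring of carbon only bearing a propyl chain without loss of a measurable effect. Compound 2 stands at a limit of the assay and not at a number, so the true size of the step remains unknown: the limit of > 50000 nM in this assay, at which 1 of the 3 values shown sits.

The compounds shown leave open whether the ring or the propyl chain carries the step, as a plain cyclohexyl or a longer chain on the ring could tell. They also leave open how an amine or a methyl ester would behave at this position.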